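Chloro on the urea phenyl of compound 3

The compounds below may be only part of what the source reports. "The series", "measured", "known", "first", "only" and "open" are said of these compounds alone.

Compound 3 `CCN(CC)CCCNc1nc(-c2ccc(NC(=O)Nc3ccccc3)cc2)nc2ccsc12` gives 980 nM in a functional assay on MKN-45 cells (Homo sapiens) for cytotoxicity, read by MTT assay, with a stated time of 72 h (on this read-out lower numbers stand for stronger inhibition and higher numbers for weaker inhibition), the lowest of the three numbers, though both others sit within the scatter of it: compound 1 `CN(C)CCNc1nc(-c2ccc(NC(=O)Nc3ccccc3)cc2)nc2ccsc12` gives 1120 nM and compound 2 `CN(C)CCNc1nc(-c2ccc(NC(=O)Nc3ccc(F)cc3)cc2)nc2c(Cl)c(Cl)sc12` gives 1350 nM. Within the data shown here, the only single-point step measured, a 1.1-fold lower number from compound 1 to compound 3 (0.06 log units; within the scatter), touches the amine end of the chain and not the urea. Compound 4 `CCN(CC)CCCNc1nc(-c2ccc(NC(=O)Nc3ccccc3Cl)cc2)nc2ccsc12` differs from compound 3 by chloro in place of hydrogen on an aromatic carbon. Among the measured compounds shown here, no measured step alters the phenyl of the urea, so nothing bears directly on this change. A step not beyond the scatter is therefore expected in this assay, with no settled direction. Compound 4 is estimated at 900 nM, within 400 nM to 2200 nM, an expected step of a 1.1-fold lower number from compound 3 to compound 4 (0.04 log units; within the scatter).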

Compound 4, half-maximal inhibitory concentration: 390 nM
Compound 4: middle estimate off by 2.3-fold (0.36 log units), on the high side, and the stated range ends above it.
By their numbers in this assay, from the lowest: compound 4; then compounds 3, 1 and 2 (each within the scatter of the next).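

In this assay, among these compounds, the phenyl of the urea responds to substitution: chloro ortho to a large group gives a 2.5-fold lower number from compound 3 to compound 4 (0.40 log units; beyond the scatter), the only step beyond the scatter. The earlier step, at the amine end of the chain, showed no such change. Nothing at hand gives a reason for this step.

Open, on these data alone, is whether the step belongs to chloro itself or to this place on the ring; bromo or methoxy at the same carbon would bear on that. Also open, as far as these compounds go, is whether 2-chlorophenyl gives a similar step on the shorter dimethylamino chain of compound 1.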